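The source may hold more compounds than are shown below. What is called first, only, known or untested is meant among the compounds shown, and "the series" means these compounds.

Three compounds were measured in an assay on HEK293 cells for inhibition of Voltage-dependent N-type calcium channel subunit alpha-1B (Homo sapiens), read by FLIPR and calcium flux, tested at 1 uM; a higher number here means more inhibition at the concentration tested (going by the name of the read-out), a lower number less inhibition. Compound 1 `CS(=O)(=O)c1ccc(C(=O)N2CCC(N(C3CC3)S(=O)(=O)c3cccc(C(F)(F)F)c3)CC2)cc1` gives 52% in this assay. Going by the values given here, compound 2 `NC(=O)c1ccccc1C(=O)N1CCC(N(C2CC2)S(=O)(=O)c2cccc(C(F)(F)F)c2)CC1` gives 15%, and the step of a number 37 percentage points lower from compound 1 to compound 2 (beyond the scatter) is the only one-place comparison among the measured pairs. Compound 3 `CS(=O)(=O)c1ccc(F)cc1C(=O)N1CCC(N(C2CC2)S(=O)(=O)c2ccc(C(F)(F)F)cc2)CC1` gives 1%, the lowest of the three numbers, sitting beyond the scatter below both compound 2 and compound 1.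

Compound 4 `CS(=O)(=O)c1ccc(F)cc1C(=O)N1CCC(N(C2CC2)S(=O)(=O)c2ccc(OC(F)(F)F)cc2)CC1` is not yet measured. It differs from compound 3 in one place: trifluoromethoxy in place of trifluoromethyl on an aromatic carbon. Among the compounds with values here, no measured step touches this part of the molecule, since the step from compound 1 to compound 2 changes a different group, so there is no guide to the size of the effect. Compound 4 is therefore expected to stay close to compound 3, with an estimated step of a number 4 percentage points higher from compound 3 to compound 4 (within the scatter). Compound 4 is estimated at 5%, within a range from 0% to 25%.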

Compound 4, a percentage reported as inhibition, at one concentration (the size of the read-out at that concentration, not a potency): 0%
Compound 4: the middle estimate sits 5 percentage points above what was measured; the range from low to high includes it.
By their numbers in this assay, from the lowest: compounds 4 and 3 (each within the scatter of the next); then compound 2; then compound 1.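

Trifluoromethoxy in place of trifluoromethyl on this aromatic carbon gives a number 1 percentage points lower from compound 3 to compound 4 (within the scatter) in this assay, the first step shown that stays within the scatter. Compound 3 already sat near the bottom of the scale, so this step could not show a further loss, and it says little about how much this position matters. No measured evidence bears on this result. From the compounds shown here alone, whether an amine or a carboxylic acid at this position would raise the number stays open, as does what the same swap would do on a compound with a higher starting value, such as compound 1.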